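The compounds below may be only part of what the source reports. "The series", "measured", "known", "first", "only" and "open" are said of these compounds alone.

Measured compounds in a functional assay on NCI-H460 cells (Homo sapiens) for cytotoxicity, read by MTT assay, with a stated time of 48 h; a lower number here means a stronger inhibitor, a higher number a weaker inhibitor:
compound 1 `O=c1[nH]c2ccccc2cc1-c1nc2cc(Br)ccc2[nH]1` gives 16800 nM;
compound 2 `O=c1[nH]c2ccccc2cc1-c1nc2cc([N+](=O)[O-])ccc2[nH]1` shows only the limit > 100000 nM, not a number;
compound 3 `Cc1ccc2[nH]c(=O)c(-c3nc4cc(Cl)ccc4[nH]3)cc2c1` gives 36500 nM.

Compound 3 thus stands highest of the two numbers, with compound 1 the nearest at a lower number. Among the measured compounds shown here, the one measured step, an at least 5.9-fold higher number from compound 1 to compound 2 (0.77 log units; beyond the scatter), concerns the substituent on the other ring and is sensitive to the limit of > 100000 nM in this assay, at which 1 of the 3 values shown sits.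

Compound 4 `O=c1[nH]c2ccccc2cc1-c1nc2cc(Cl)ccc2[nH]1` differs from compound 3 by hydrogen in place of methyl on an aromatic carbon. For the measured compounds named here, no measured step bears on this change, so no direction beyond the scatter is grounded; compound 1 shows where an analog without the methyl and with bromo stands. Compound 4 is therefore expected near 22000 nM in this assay, range 8000 nM to 60000 nM, a step of a 1.7-fold lower number from compound 3 to compound 4 (0.22 log units; within the scatter).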

Compound 4, half-maximal inhibitory concentration: 14700 nM
Estimate against measurement, compound 4: 1.5-fold (0.18 log units) above; the measured number falls inside the stated range.
By their numbers in this assay, from the lowest: compounds 4 and 1 (each within the scatter of the next); then compound 3. At a limit, above all of these: compound 2.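

With chloro held fixed, hydrogen in place of methyl on an aromatic carbon gives a 2.5-fold lower number from compound 3 to compound 4 (0.39 log units; beyond the scatter), so this position responds to even a single added carbon. Chloro in place of bromo gives a 1.1-fold lower number from compound 1 to compound 4 (0.06 log units; within the scatter), so bromo and chloro cannot be told apart here. Chloro in place of nitro gives an at least 6.8-fold lower number from compound 2 to compound 4 (0.83 log units; beyond the scatter), and this step rests on a limit for compound 2, not a number: the limit of > 100000 nM in this assay, at which 1 of the 4 values shown sits.

On these data alone, whether an ethyl or a methoxy group at the methyl position would follow the methyl remains open. As far as these compounds go, how an amine in place of chloro would stand is also open.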